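A few compounds are considered here, and "the series" means these few. Any claim that something is new, unique, unknown or untested is made for them only; others in the source may bear on it.

Working notes on the series, read in a functional assay (muscle tissue) with Cavia porcellus as the target; on this read-out higher numbers stand for an effect only at larger amounts of compound and lower numbers for an effect already at smaller amounts. Compound 1 (`COC(=O)C1=C(C)N=C(C)/C(=C(\O)OC)C1c1ccc(Cl)cc1`), with 4-chlorophenyl, gives 8130 nM. Compound 2 (`COC(=O)C1=C(C)N=C(C)/C(=C(\O)OC)C1c1ccccc1F`), with 2-fluorophenyl, gives 42.7 nM. Compound 3 (`COC(=O)C1=C(C)N=C(C)/C(=C(\O)OC)C1c1cccc(C#N)c1`), with 3-cyanophenyl, gives 34.7 nM. Compound 3 therefore stands at the low end of the three numbers, level with compound 2 within the scatter and far from compound 1.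

The next change gives compound 4 (`COC(=O)C1=C(C)N=C(C)/C(=C(\O)OC)C1c1ccccc1C`): 2-methylphenyl in place of 3-cyanophenyl on a saturated ring carbon, (2-methylphenyl in place of 3-cyanophenyl on a saturated ring carbon).

Among the measured compounds shown here, the steps that bear on it are a 190-fold lower number from compound 1 to compound 2 (2.28 log units; beyond the scatter) and a 230-fold lower number from compound 1 to compound 3 (2.37 log units; beyond the scatter), both large, and a 1.2-fold lower number from compound 2 to compound 3 (0.09 log units; within the scatter), within the scatter. Only the 4-chlorophenyl of compound 1 stands apart so far. The 2-methylphenyl group shares its substitution place with the 2-fluorophenyl of compound 2, which gives 42.7 nM, so a number near that pair is expected in this assay, with no step beyond the scatter and no firm direction. The expected step is a 1.7-fold higher number from compound 3 to compound 4 (0.24 log units; within the scatter). For compound 4 the estimated value is 60 nM, with an expected range from 15 nM to 300 nM.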

Compound 4, half-maximal effective concentration: 6.03 nM
The estimate for compound 4 lay 10-fold (1.00 log units) above the measured number; the measured number lies below the stated range.
By their numbers in this assay, from the lowest: compound 4; then compounds 3 and 2 (each within the scatter of the next); then compound 1.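

In this assay, methyl in place of fluoro on the same aromatic carbon gives a 7.1-fold lower number from compound 2 to compound 4 (0.85 log units; beyond the scatter) and so separates two groups that share one substitution place on the phenyl ring. The level pair of 2-fluorophenyl and 3-cyanophenyl does not mark the low end of the series, since 2-methylphenyl gives a 5.8-fold lower number from compound 3 to compound 4 (0.76 log units; beyond the scatter) and the span from the 4-chlorophenyl of the series widens to a 1300-fold lower number from compound 1 to compound 4 (3.13 log units; beyond the scatter) in this comparison. Nothing measured on these compounds accounts for the gap between methyl and fluoro on this carbon.

Open, on these data alone, is whether an ethyl or methoxy group on that aromatic carbon follows the methyl or the fluoro. Also open, as far as these compounds go, is how far the high number of compound 1 belongs to the chloro group itself and how far to where it sits, as a chloro group on the aromatic carbon that carries methyl in compound 4 would show.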